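Nitro in place of ethoxy: compound 1 to compound 3

A few compounds are considered here, and "the series" means these few. Any claim that something is new, unique, unknown or untested is made for them only; others in the source may bear on it.

Measured compounds:
compound 1, `CCOc1ccccc1OCCSC(=S)N[C@H]1CCOC1=O`, 24100 nM
compound 2, `CC(C)(C)c1ccc(/C=C/C(=O)c2ccc(OCC(=O)N[C@H]3CCOC3=O)cc2)cc1`, 10600 nM

In a functional assay on PC-3 cells (Homo sapiens) for antiproliferative activity, read by MTT assay, with a stated time of 72 h (on this read-out lower numbers stand for stronger inhibition and higher numbers for weaker inhibition), compound 1 gives 24100 nM, the highest of the two numbers recorded so far. The nearest neighbour is compound 2, which in this assay gives 10600 nM; its gap to compound 1 lies beyond the usual scatter. Within the data shown here, the two structures differ in more than one place, so no single step links them, and only the two values themselves can be read.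

The next compound is compound 3, `O=C1OCC[C@@H]1NC(=S)SCCOc1ccccc1[N+](=O)[O-]`. It differs from compound 1 in one place: nitro in place of ethoxy on an aromatic carbon

Among the measured compounds shown here, no measured pair shows this exchange, so the size of its effect in this assay is unknown. With nothing to anchor a shift in either direction, the expectation is a step of modest size at most, possibly none beyond the scatter, in this assay from compound 1 to compound 3, which is estimated as a 1.2-fold lower number from compound 1 to compound 3 (0.08 log units; within the scatter). Compound 3 is accordingly expected to give about 20000 nM in this assay, with a range from 8000 nM to 50000 nM.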

Compound 3, half-maximal inhibitory concentration: 24000 nM
Beside the measured number, compound 3's estimate is 1.2-fold (0.08 log units) below it; the range from low to high includes it.
By their numbers in this assay, from the lowest: compound 2; then compounds 3 and 1 (each within the scatter of the next).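

In this assay, among these compounds, nitro in place of ethoxy on an aromatic carbon, ortho to a large group, gives a 1.0-fold lower number from compound 1 to compound 3 (0.00 log units; within the scatter), and this is the first single-place comparison available. The two groups have the same heavy-atom count but differ in their atoms and in their hydrogen-bond acceptor counts, yet this read-out does not separate them at this position, so the exchange is tolerated here within the scatter. Among the compounds shown here, nothing measured so far bears on this result.

The compounds shown leave open how an amine, a carboxylic acid or a longer alkoxy chain would read at this position, and whether a plain hydrogen there would read alike. Also open, on these data alone, is whether the exchange of nitro for ethoxy would read the same on another carbon of the ring or on another core.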